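Trichloromethyl for trifluoromethyl on the core of compound 1

The source may hold more compounds than are shown below. What is called first, only, known or untested is meant among the compounds shown, and "the series" means these compounds.

In a physicochemical assay for acid dissociation, compound 1 `CC(=O)Nc1ccc(OC(=S)Nc2ccc(Nc3ccc(C(F)(F)F)cc3)cc2)cc1` gives 9.05. Compound 2 `Oc1ccc(OC(=S)Nc2ccc(Nc3ccc(C(F)(F)F)cc3)cc2)cc1` gives 9.23 and compound 3 `Oc1ccc(OC(=S)Nc2ccc(Oc3ccc(C(Cl)(Cl)Cl)cc3)cc2)cc1` gives 9.24; both numbers lie within the scatter of compound 1, so the three are not told apart. For the measured compounds named here, the only single-point step measured, a number 0.18 log units higher from compound 1 to compound 2 (within the scatter), touches the acetamido end of the molecule and not the aryl group that changes here. Compound 4 `CC(=O)Nc1ccc(OC(=S)Nc2ccc(Nc3ccc(C(Cl)(Cl)Cl)cc3)cc2)cc1` carries trichloromethyl in place of trifluoromethyl on an aromatic carbon. Going by the values given here, compounds 2 and 3 differ at this carbon and also at the linker, and their two values lie together; no step in this assay isolates the trichloromethyl change. No movement beyond the scatter is therefore expected, no change at the digits printed from compound 1 to compound 4 (within the scatter). Compound 4 is estimated at 9.05, within 8.75 to 9.35.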

Compound 4, acid dissociation constant: 9.01
Estimate against measurement, compound 4: 0.04 log units above, within the range that was stated.
By their numbers in this assay, from the lowest: compounds 4, 1, 2 and 3 (each within the scatter of the next).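

In this assay, exchanging the trifluoromethyl group for a trichloromethyl group on the aromatic carbon para to a large group gives a number 0.04 log units lower from compound 1 to compound 4 (within the scatter), so compound 1 and compound 4 are not told apart. For the compounds shown here, no earlier single-place step touched this position, and this step now isolates the change. No available measurement bears on a cause for this result.

Open, from the compounds shown here alone, is whether a different group on this carbon, such as an amine or a carboxylic acid, would move the number beyond the scatter. Also open, going by these compounds, is whether the same change reads alike on the core of compound 2, with hydroxy in place of acetamido.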